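A few compounds are considered here, and "the series" means these few. Any claim that something is new, unique, unknown or untested is made for them only; others in the source may bear on it.

Of the compounds shown here, three have been measured. Compound 1, `CCOC(=O)C1=Cc2ccccc2OC1(OCc1cc(-c2ccc(F)cc2F)no1)C(F)(F)F`, is reported in a functional assay on HeLa cells (Homo sapiens) for inhibition, read by MTT assay, with a stated time of 24 h (a lower number here means a stronger inhibitor, a higher number a weaker inhibitor), only as the limit > 150000 nM. Compound 2, `CCOC(=O)C1=Cc2ccccc2OC1(OCc1cn(CC(=O)Nc2cccc(Cl)c2)nn1)C(F)(F)F`, gives in this assay a value of 12300 nM. Compound 3, `CCOC(=O)C1=Cc2ccccc2OC1(OCc1cc(-c2ccc(C)cc2)no1)C(F)(F)F`, is reported in this assay only as the limit > 150000 nM.

For the measured compounds named here, compound 2 therefore carries the only number in the set; the other two entries sit at the limit of > 150000 nM in this assay, at which 2 of the 3 values shown sit. The lone measured step runs between compounds 1 and 3: a step that the two limits leave unreadable from compound 1 to compound 3. That change sits on an aromatic carbon of another part of the shared core, and with both ends at a limit it shows neither size nor direction.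

Compound 4, `CCOC(=O)C1=Cc2ccccc2OC1(OCc1cn(CC(=O)Nc2ccc(C)cc2)nn1)C(F)(F)F`, has not yet been measured. It differs from compound 2 in one place: 4-methylphenyl in place of 3-chlorophenyl on an amide-type nitrogen. Going by the values given here, no measured step touches this amide nitrogen, and the one step that is measured is unreadable, so the only firm guide is that compound 2 gave a number at all. For compound 4 the expected step is a 1.5-fold higher number from compound 2 to compound 4 (0.17 log units; within the scatter), no change beyond the scatter, though the range must be wide. Compound 4 is therefore expected to give in this assay about 18000 nM, between 5000 nM and 70000 nM.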

Compound 4, half-maximal inhibitory concentration: 67400 nM
Beside the measured number, compound 4's estimate is 3.7-fold (0.57 log units) below it, within the range that was stated.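

In this assay, for the compounds shown here, the first readable step of the set falls on the amide-type nitrogen: 4-methylphenyl in place of 3-chlorophenyl gives a 5.5-fold higher number from compound 2 to compound 4 (0.74 log units; beyond the scatter), a modest loss of strength beyond the scatter. Going by these compounds alone, the earlier compounds could not show this, since the only step among them cannot be read, whereas this one shows that the aromatic group on this nitrogen affects the read-out even though the two groups match in heavy-atom count and in ring type. Nothing measured here gives a cause for this step.

The change swaps the substituent and its ring position together, so the compounds shown cannot separate the loss of the chlorine, the gain of the methyl and the move around the ring. As far as these compounds go, how an unsubstituted phenyl, or a phenyl ring bearing an amine or a carboxylic acid, would behave on this nitrogen remains open, as does whether any group here could give a lower number than compound 2 does.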